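A few compounds are considered here, and "the series" means these few. Any claim that something is new, unique, unknown or untested is made for them only; others in the source may bear on it.

In an ADME assay on a cell-free system (plasma, Homo sapiens) for protein binding, compound 1 `COCCc1nc2nc(C)cc(Nc3ccc(S(F)(F)(F)(F)F)cc3)n2n1` gives 87.7% and compound 2 `CSc1nc2nc(C)cc(Nc3ccc(S(F)(F)(F)(F)F)cc3)n2n1` gives 97.7%. Of these two, compound 2 has the lower unbound fraction. Among the compounds with values here, the only measured step is a 5.3-fold lower unbound fraction from compound 1 to compound 2 (0.73 log units; beyond the scatter), and it exchanges 2-methoxyethyl for methylsulfanyl on an aromatic carbon of the shared core.

The next structure, compound 3 `Cc1cc(Nc2ccc(S(F)(F)(F)(F)F)cc2)n2nc(C(C)(F)F)nc2n1`, keeps that core and puts 1,1-difluoroethyl in place of methylsulfanyl on the same aromatic carbon: 1,1-difluoroethyl in place of methylsulfanyl on an aromatic carbon. Within the data shown here, no measured compound carries 1,1-difluoroethyl, so there is no direct guide to this exchange. Among the measured compounds shown here, the one measured step, a 5.3-fold lower unbound fraction from compound 1 to compound 2 (0.73 log units; beyond the scatter), shows only that a change at this carbon can move the read-out beyond the scatter. One uncharged group without a ring replaces another, so no shift beyond the scatter is expected, although a shift of similar size in either direction cannot be ruled out. The estimated change is a 1.1-fold higher unbound fraction from compound 2 to compound 3 (0.04 log units; within the scatter). For compound 3 the estimate is 97.5%, with an expected range from 93% to 99.5%.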

Compound 3, plasma protein binding: 97.4%
Compound 3: the middle estimate sits 1.0-fold (0.02 log units) (unbound fraction) below what was measured; the range from low to high includes it.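

In this assay, the step a 1.1-fold higher unbound fraction from compound 2 to compound 3 (0.05 log units; within the scatter) shows that this aromatic carbon, between two ring nitrogen atoms, does not respond to every exchange: methylsulfanyl, with its sulfur and hydrogen-bond acceptor, and 1,1-difluoroethyl, with two fluorine atoms and no hydrogen-bond acceptor, cannot be told apart in this read-out. The step a 4.7-fold lower unbound fraction from compound 1 to compound 3 (0.67 log units; beyond the scatter) lies beyond the scatter, as does a 5.3-fold lower unbound fraction from compound 1 to compound 2 (0.73 log units; beyond the scatter), so among the three groups at this carbon, 2-methoxyethyl is now the one that stands apart, leaving more of the compound free than either of the other two. Within the data shown here, no independent measurement is available to explain this pattern, which rests on only three compounds.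

From the compounds shown here alone, it remains open whether the oxygen or the chain of 2-methoxyethyl sets compound 1 apart, a question that a plain propyl chain at the same carbon would help to settle. All three groups are free of rings and carry no net charge, so the compounds shown also leave open how an amine, a carboxylic acid or a phenyl ring would behave there.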